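Sodium/Hydrogen Exchanger Inhibitors: Pyrazolyl Replaces Hydroxy

A few compounds are considered here, and "the series" means these few. Any claim that something is new, unique, unknown or untested is made for them only; others in the source may bear on it.

Compound 1 `Cc1cc(-c2ccc(Cl)cc2)c(S(C)(=O)=O)cc1C(=O)N=C(N)N`: 45 nM
Compound 2 `Cc1cc(O)c(S(C)(=O)=O)cc1C(=O)N=C(N)N`: 220 nM

In a functional assay for inhibition of sodium/hydrogen exchanger (Oryctolagus cuniculus) (a higher number here means a weaker inhibitor, a lower number a stronger inhibitor), compound 2 stands highest of the two measured numbers. Among the measured compounds shown here, the only step so far, a 4.9-fold higher number from compound 1 to compound 2 (0.69 log units; beyond the scatter), shows that an aromatic ring at this position gives a lower number than hydroxy. Compound 3 `Cc1cc(-n2cccn2)c(S(C)(=O)=O)cc1C(=O)N=C(N)N` carries a ring at the same place: 1H-pyrazol-1-yl in place of hydroxy on an aromatic carbon. Because a 4.9-fold higher number from compound 1 to compound 2 (0.69 log units; beyond the scatter) went beyond the scatter, a return toward a lower number is expected for compound 3, though a smaller one, since the entering ring differs from the leaving chlorophenyl; compound 3 is expected at 90 nM, between 35 nM and 250 nM, a step of a 2.4-fold lower number from compound 2 to compound 3 (0.39 log units; beyond the scatter).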

Compound 3, half-maximal inhibitory concentration: 25 nM
Compound 3: the middle estimate sits 3.6-fold (0.56 log units) above what was measured; the measured number lies below the stated range.
By their numbers in this assay, from the lowest: compounds 3 and 1 (each within the scatter of the next); then compound 2.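

The step of an 8.8-fold lower number from compound 2 to compound 3 (0.94 log units; beyond the scatter) shows that the gain at this position does not depend on a chlorophenyl group, since a five-membered aromatic ring with 2 hetero atoms also gives a much lower number than hydroxy. With a 1.8-fold lower number from compound 1 to compound 3 (0.26 log units; within the scatter), 1H-pyrazol-1-yl and 4-chlorophenyl cannot be told apart in this assay. No supporting data bear on why these rings differ from hydroxy.

Going by these compounds, whether an aromatic ring is needed at all remains open, as a small amine or a methoxy group could answer. A saturated ring such as piperidine would ask the same question.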